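This account rests on a few compounds, and the source may have more. Where it says the series, first, only, none or still open, it means among the compounds named here.

Working notes on the series. In a functional assay on PC-3 cells (Homo sapiens) for inhibition, read by MTT assay (a lower number here means a stronger inhibitor, a higher number a weaker inhibitor), compound 3 (`O=C(CCCCCCC(=O)Nc1nnc(-c2cccs2)s1)NO`) gives 880 nM, level with compound 1 (`O=C(CCCCCCC(=O)Nc1nnc(-c2ccco2)s1)NO`) at 880 nM; these two share the highest number of the three measured. Compound 2 (`N#Cc1cccc(-c2cn(CCCCCCn3cccc(/C=C/C(=O)NO)c3=O)nn2)c1`), of a different build, gives 600 nM, and its gap to compound 3 lies within the scatter, so the three values sit together.

Compound 4 (`Cc1ccc(-c2nnc(NC(=O)CCCCCCC(=O)NO)s2)s1`) keeps everything in compound 3 except one site, thiophen-2-yl to 5-methylthiophen-2-yl: methyl in place of hydrogen on an aromatic carbon.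

Among the measured compounds shown here, only one measured step touches this end of the molecule, and it exchanges furan-2-yl for thiophen-2-yl: no change at the digits printed from compound 1 to compound 3 (within the scatter). For the measured compounds named here, no measured step adds a methyl, so the evidence is indirect and thin. On the strength of that one step, no shift beyond the scatter is expected in this assay, and no direction is favoured with any confidence.

The expected step is a 1.1-fold lower number from compound 3 to compound 4 (0.04 log units; within the scatter), which is an estimate and stays within the scatter. For compound 4 the estimated value is 800 nM, with an expected range of 380 nM to 1700 nM.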

Compound 4, half-maximal inhibitory concentration: 880 nM
For compound 4 the middle estimate is 1.1-fold (0.04 log units) below the measured one, within the range that was stated.
By their numbers in this assay, from the lowest: compounds 2, 1, 3 and 4 (each within the scatter of the next).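

In this assay, the first measured methyl at this end of the molecule gives no change at the digits printed from compound 3 to compound 4 (within the scatter), so adding this one carbon on the thiophene, on the ring carbon next to the ring sulfur, leaves the read-out where it was. The step that combines both changes at this end, 5-methylthiophen-2-yl in place of furan-2-yl, reads no change at the digits printed from compound 1 to compound 4 (within the scatter), so the flat result seen for the ring exchange alone also holds with the methyl added, across the three compounds that share this chain. Nothing measured here offers an explanation for why these values coincide.

Only hydrogen and methyl are shown at this ring carbon, so it remains open whether a larger or differently built group there, such as a carboxylic acid, an amine or a phenyl ring, would move the number in this assay at all. The same question stands for the other end of these compounds, where a longer chain or a shorter chain in place of the one shared by compound 1, compound 3 and compound 4 might show whether the read-out responds to changes there.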